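A few compounds are considered here, and "the series" means these few. Any claim that something is new, unique, unknown or untested is made for them only; others in the source may bear on it.

Measured in a physicochemical assay for solubility, measured as kinetic solubility, with a stated time of 1 h, at pH 7.4; a higher number here means a more soluble compound, a lower number a less soluble compound:
- Compound 1 `N#CCC(=O)Nc1cccc(-c2ccc(Cl)c(Cl)c2)n1`: 1000 nM
- Compound 2 `CC(=O)NC1=NN(c2ccc(Cl)c(Cl)c2)CC1`: 31000 nM

Of these two compounds, compound 2 stands higher at 31000 nM, while compound 1 gives 1000 nM, a gap well beyond the usual scatter of repeated measurements. The two differ in more than one place, so their values show only that gap and cannot be tied to any single structural change.

The next compound is compound 3 `O=C(NC1=NN(c2ccc(Cl)c(Cl)c2)CC1)c1ccncc1`, which has pyridin-4-yl in place of methyl on a carbonyl carbon of compound 2: pyridin-4-yl in place of methyl on a carbonyl carbon. Among the measured compounds shown here, no measured step speaks directly to this change, so the expectation rests on thin ground. For the measured compounds named here, compound 2, at 31000 nM, holds the higher of only two values, and the entering group is much larger than the one that leaves. A downward move in this assay, beyond the scatter, is therefore expected, and the expected size is a 3.9-fold lower number from compound 2 to compound 3 (0.59 log units; beyond the scatter). The estimate for compound 3 is 8000 nM, with an expected range from 2000 nM to 25000 nM.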

Compound 3, solubility: 9000 nM
Compound 3: the middle estimate sits 1.1-fold (0.05 log units) below what was measured, within the range that was stated.
By their numbers in this assay, from the lowest: compound 1; then compound 3; then compound 2.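

Among the compounds shown here, measured in this assay the replacement of methyl by pyridin-4-yl on a carbonyl carbon gives a 3.4-fold lower number from compound 2 to compound 3 (0.54 log units; beyond the scatter), and this is the first difference that can be tied to a single place. It shows that the group on this carbonyl carbon, whose other neighbour is an amide-type nitrogen, does register in this read-out, since the step lies beyond the usual scatter, though it is only modest. No measurement at hand accounts for the direction or the size of this step, so it stands as an observation without an explanation.

From the compounds shown here alone, with one step at this place, it remains open whether the change follows the aromatic ring as a whole or its ring nitrogen, a question that a phenyl group on the same carbonyl carbon would address. Also open, going by these compounds, is how this assay would respond to a longer alkyl chain, an amine or a carboxylic acid at this place, and whether pyridin-4-yl would give a similar step on the core of compound 1.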